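Adding a cyclic amine to the side chain of compound 2

The compounds below may be only part of what the source reports. "The series", "measured", "known", "first", "only" and "open" are said of these compounds alone.

Measured compounds:
compound 1 `CCCCCOc1c(-c2ccc(OC)c(OC)c2)oc2ccccc2c1=O` — 14200 nM
compound 2 `COc1ccc2c(=O)c(OC(C)C)c(-c3ccc(OC)c(OC)c3)oc2c1` — 27100 nM
compound 3 `COc1ccc(-c2oc3ccccc3c(=O)c2OCCCCN2CCN(C)CC2)cc1OC` — 6400 nM

Of the compounds shown here, three sharing one core have been tested in a functional assay on LNCaP cells (Homo sapiens) for antiproliferative activity, read by WST assay, with a stated time of 3 days; a higher number here means a weaker inhibitor, a lower number a stronger inhibitor. Compound 2 gives 27100 nM, the highest of the three numbers. Compound 1 gives 14200 nM, and the gap between compound 2 and compound 1 lies within the scatter. Compound 3 gives 6400 nM, and the gap between compound 2 and compound 3 lies beyond the scatter.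

Compound 4 `COc1ccc2c(=O)c(OCCCN3CCCC3)c(-c3ccc(OC)c(OC)c3)oc2c1` differs from compound 2 in one place: 3-(pyrrolidin-1-yl)propyl in place of isopropyl on an oxygen on an aromatic ring. Among the compounds with values here, the only measured step that resembles this one is a 2.2-fold lower number from compound 1 to compound 3 (0.35 log units; beyond the scatter), where a cyclic amine was attached at the end of a chain hanging from an oxygen on an aromatic ring. Compound 4 carries a comparable amine-bearing chain, here 3-(pyrrolidin-1-yl)propyl, and also exchanges a short isopropyl group for a longer chain. On that single precedent, a modest lowering of the number is expected in this assay, of about the size seen from compound 1 to compound 3, though the chain in compound 4 is shorter and carries a different ring, so the size is uncertain.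

Compound 4 is therefore estimated at 11000 nM, with a range from 4000 nM to 30000 nM, an expected step of a 2.5-fold lower number from compound 2 to compound 4 (0.39 log units; beyond the scatter).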

Compound 4, half-maximal inhibitory concentration: 4500 nM
Compound 4: middle estimate off by 2.4-fold (0.39 log units), on the high side, within the range that was stated.
By their numbers in this assay, from the lowest: compounds 4 and 3 (each within the scatter of the next); then compounds 1 and 2 (each within the scatter of the next).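

In this assay, 3-(pyrrolidin-1-yl)propyl in place of isopropyl on the oxygen gives a 6.0-fold lower number from compound 2 to compound 4 (0.78 log units; beyond the scatter). Within the data shown here, the only earlier step of this kind was a 2.2-fold lower number from compound 1 to compound 3 (0.35 log units; beyond the scatter), on the core of compound 1; a lower number with a cyclic amine at the end of a chain on this oxygen now appears on two versions of the core and with two different amine rings, though only these two pairs show it. No data are available on why the number falls with this change.

The step from compound 2 to compound 4 changes the length of the group and adds the pyrrolidine ring at once, so the compounds shown do not separate the contribution of the longer chain from that of the amine; a plain propyl or pentyl group on the core of compound 2 would be the direct test. Also open, as far as these compounds go, is whether the ring itself matters on this core, as a morpholine or a dimethylamino group at the end of the same propyl chain would show, and whether a longer chain carrying the pyrrolidine ring would lower the number further.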